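Acetamido on the coumarin core of a furoxan sulfone

The source may hold more compounds than are shown below. What is called first, only, known or untested is meant among the compounds shown, and "the series" means these compounds.

Measured so far:
compound 1, `COc1cc2ccc(=O)oc2cc1OCCCOc1no[n+]([O-])c1S(=O)(=O)c1ccccc1`: 2270 nM
compound 2, `COc1cc2ccc(=O)oc2cc1OCCCCOc1no[n+]([O-])c1S(=O)(=O)c1ccccc1`: 3040 nM

In a functional assay on MCF7 cells (Homo sapiens) for inhibition, read by MTT assay, with a stated time of 48 h (on this read-out lower numbers stand for stronger inhibition and higher numbers for weaker inhibition), compound 1 gives 2270 nM and compound 2 gives 3040 nM; the two numbers sit within the usual scatter of each other, so neither can be ranked. Compound 3, `COc1cc2cc(NC(C)=O)c(=O)oc2cc1OCCCOc1no[n+]([O-])c1S(=O)(=O)c1ccccc1`, carries acetamido in place of hydrogen on an aromatic carbon on the shared core of compound 1. Going by the values given here, no measured pair shows what such a change does here, so the step of a 1.1-fold higher number from compound 1 to compound 3 (0.06 log units; within the scatter) is expected to be small, in either direction or none beyond the scatter. Compound 3 is therefore estimated at 2600 nM in this assay, with a range from 800 nM to 8500 nM.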

Compound 3, half-maximal inhibitory concentration: 2400 nM
Compound 3: the middle estimate sits 1.1-fold (0.03 log units) above what was measured; low and high end bracket the measured number.
By their numbers in this assay, from the lowest: compounds 1, 3 and 2 (each within the scatter of the next).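

Going by these compounds alone, the step of a 1.1-fold higher number from compound 1 to compound 3 (0.02 log units; within the scatter) in this assay is the first reading at this position, and it shows that acetamido in place of hydrogen on this aromatic carbon, two atoms from the ring oxygen, leaves no difference that can be read. The position of the shared core therefore accommodates these 4 extra heavy atoms in this assay. Nothing measured here explains the result.

On these data alone, whether a free amine, a carboxylic acid or a longer acyl chain on this carbon would read the same remains open. So does whether acetamido would read alike on the longer chain of compound 2.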